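This account rests on a few compounds, and the source may have more. Where it says the series, first, only, none or still open, it means among the compounds named here.

Measured so far in a functional assay on C6 cells (Rattus norvegicus) for cytotoxicity, read by MTT assay, with a stated time of 24 h, tested at 100 ug/mL; on this read-out lower numbers stand for a stronger effect and higher numbers for a weaker effect at the one concentration tested:
compound 1, `O=C(CSc1nnnn1-c1ccccc1)N/N=c1/scc(-c2ccc(Br)cc2)n1-c1ccccc1`, 24.3%
compound 2, `O=C(CSc1ncccn1)N/N=c1/scc(-c2ccc(Br)cc2)n1-c1ccccc1`, 67.6%
compound 3, `Cn1nnnc1SCC(=O)N/N=c1/scc(-c2ccc([N+](=O)[O-])cc2)n1-c1ccccc1`, 64.1%

Compound 2 stands highest of the three numbers. Its nearest neighbour is compound 3, within the scatter, so no order between these two is claimed. Compound 1 lies well below it; the step of a number 43.3 percentage points higher from compound 1 to compound 2 (beyond the scatter) is the only one in the set that differs in a single place, and it concerns the group on the sulfur.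

Compound 4, `COc1ccc(-c2cs/c(=N/NC(=O)CSc3ncccn3)n2-c2ccccc2)cc1`, is not yet measured. It differs from compound 2 in one place: methoxy in place of bromo on an aromatic carbon. For the measured compounds named here, no measured step bears on this change: the single-place step known so far alters the group on the sulfur and leaves the aromatic ring untouched, so there is nothing to set a direction or a size for a change on that ring. Going by the values given here, with no step to lean on, no change beyond the scatter is expected, and the estimated step is a number 0.6 percentage points lower from compound 2 to compound 4 (within the scatter). Compound 4 is expected at 67%, within a range from 48% to 86%.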

Compound 4, a percentage reported as activity, at one concentration (the size of the read-out at that concentration, not a potency): 51.5%
Compound 4: middle estimate off by 15.5 percentage points, on the high side, within the range that was stated.
By their numbers in this assay, from the lowest: compound 1; then compound 4; then compounds 3 and 2 (each within the scatter of the next).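

In this assay, the group on the aromatic ring is not neutral: 4-methoxyphenyl in place of 4-bromophenyl reads as a number 16.1 percentage points lower from compound 2 to compound 4 (beyond the scatter), which is a stronger effect at the one concentration tested. The ring therefore joins the group on the sulfur as a second place where the read-out moves, although this step is modest and the sulfur step, a number 43.3 percentage points higher from compound 1 to compound 2 (beyond the scatter), is large. No measured evidence bears on why methoxy and bromo differ here.

On these data alone, this pair reads the change only with pyrimidin-2-yl on the sulfur, so its size with 1-phenyl-1H-tetrazol-5-yl remains open, and the nitro of compound 3 cannot be placed on this scale, as compound 3 also carries a different group on the sulfur. As far as these compounds go, how an amine or a carboxylic acid would read on the same aromatic carbon also remains open.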